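This account rests on a few compounds, and the source may have more. Where it says the series, first, only, none or still open, it means among the compounds named here.

Working notes on the series in an ADME assay on HepG2 cells (Homo sapiens) for cytotoxicity, read by luminescence, CellTiter-Glo and ATP content, with a stated time of 72 h; on this read-out higher numbers stand for an effect only at larger amounts of compound and lower numbers for an effect already at smaller amounts. Compound 1 `COc1cccc(CNCCCNc2ccnc3cc(Cc4ccccc4)ccc23)c1O` gives 5720 nM. Compound 2 `COc1cccc(CNCCCNc2ccnc3cc(Cc4ccc(F)cc4)ccc23)c1O` gives 4780 nM, with a 1.2-fold lower number from compound 1 to compound 2 (0.08 log units; within the scatter). Compound 3 `COc1cccc(CNCCCNc2ccnc3cc(Oc4cccc(N(C)C)c4)ccc23)c1O` gives 7300 nM; the steps of a 1.3-fold higher number from compound 1 to compound 3 (0.11 log units; within the scatter) and a 1.5-fold higher number from compound 2 to compound 3 (0.18 log units; within the scatter) are both within the scatter, so compound 3 carries the highest number of the three but is not separable from compound 1 or compound 2 on these measurements. All three numbers sit in a narrow band.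

Compound 4 `COc1cccc(CNCCCNc2ccnc3cc(CC4CCCCC4)ccc23)c1O` has not yet been measured. Its change from compound 3: cyclohexylmethyl in place of 3-(dimethylamino)phenoxy on an aromatic carbon. For the measured compounds named here, no measured step swaps a benzyl or phenoxy-type group for a saturated ring at this position; the nearest comparisons are the step from compound 1 to compound 3 and the step from compound 2 to compound 3, which exchange one aromatic substituent for another and stay within the scatter. Going by the values given here, with no measured step pointing in either direction, the expectation for compound 4 in this assay is a step of about a 1.2-fold lower number from compound 3 to compound 4 (0.09 log units; within the scatter), no larger than the scatter. Compound 4 is therefore estimated at 6000 nM, with a range from 2500 nM to 14000 nM.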

Compound 4, half-maximal effective concentration: 970 nM
Compound 4: middle estimate off by 6.2-fold (0.79 log units), on the high side, and the stated range ends above it.
By their numbers in this assay, from the lowest: compound 4; then compounds 2, 1 and 3 (each within the scatter of the next).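

In this assay, this position turns out not to be indifferent to its substituent: exchanging the aromatic ring on the carbon bound to the shared core for a saturated one gives a 5.9-fold lower number from compound 1 to compound 4 (0.77 log units; beyond the scatter) with cyclohexyl in place of phenyl, and a 4.9-fold lower number from compound 2 to compound 4 (0.69 log units; beyond the scatter) with cyclohexyl in place of 4-fluorophenyl. The exchange of cyclohexylmethyl for 3-(dimethylamino)phenoxy gives a 7.5-fold lower number from compound 3 to compound 4 (0.88 log units; beyond the scatter), so compound 4 stands apart from all three earlier compounds, whose aromatic substituents had left their numbers within the scatter of one another. No measurement is available that bears on the reason for this separation.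

On these data alone, with a single saturated ring, it remains open whether the shift belongs to cyclohexylmethyl alone or extends to other non-aromatic groups such as cyclopentylmethyl, a straight hexyl chain or a piperidine ring. Also open, as far as these compounds go, is whether cyclohexyl joined directly to the aromatic carbon, or a longer chain between the two rings, would keep the number of compound 4 or return it to the band of compounds 1, 2 and 3.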